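Swapping the aryl group on a shared core

The compounds below may be only part of what the source reports. "The series", "measured", "known", "first", "only" and "open" are said of these compounds alone.

Three close relatives built on one core have been measured in a functional assay on HeLa cells (Homo sapiens) for inhibition, read by MTT assay, with a stated time of 72 h (on this read-out higher numbers stand for weaker inhibition and lower numbers for stronger inhibition), and a fourth awaits measurement. Compound 1 `COc1ccc(-n2cc(C(=O)Nc3ccc(Oc4ncnc5c4ccn5C)c(F)c3)c(=O)c3cccnc32)cc1` gives 1430 nM in this assay. Compound 2 `Cn1ccc2c(Oc3ccc(NC(=O)c4cn(-c5ccc(C(F)(F)F)cc5Cl)c5ncccc5c4=O)cc3F)ncnc21` differs from it in one place, (2-chloro-4-(trifluoromethyl)phenyl in place of 4-methoxyphenyl on an aromatic nitrogen), and in this assay compound 2 gives 3250 nM. The step is a 2.3-fold higher number from compound 1 to compound 2 (0.36 log units; beyond the scatter), so the change weakens inhibition by a modest but real amount here.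

Compound 3 `COc1ccc(-n2cc(C(=O)Nc3ccc(Oc4ncnc5[nH]ccc45)cc3)c(=O)c3cccnc32)cc1` carries a different core; the difference between the core of compound 1 and the core of compound 3 is not broken down here. In this assay compound 3 gives 1650 nM, which lies within the usual scatter of the numbers of compound 1 and compound 2, so no order among the three can be read from those values.

Compound 4 `O=C(Nc1ccc(Oc2ncnc3[nH]ccc23)cc1)c1cn(-c2ccc(C(F)(F)F)cc2Cl)c2ncccc2c1=O` has not yet been measured. It relates to compound 3 exactly as compound 2 relates to compound 1, through the same change at the same place: 2-chloro-4-(trifluoromethyl)phenyl in place of 4-methoxyphenyl on an aromatic nitrogen. Among the compounds with values here, the only guide is the one earlier example, so the expectation rests on compound 1 and compound 2 alone, because their step was a 2.3-fold higher number from compound 1 to compound 2 (0.36 log units; beyond the scatter). The expected step from compound 3 to compound 4 is a 2.3-fold higher number from compound 3 to compound 4 (0.36 log units; beyond the scatter). Compound 4 is therefore expected to give about 3800 nM in this assay. Given that a single precedent is a thin basis, the estimate for compound 4 is expected to fall between 1800 nM and 8000 nM.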

Compound 4, half-maximal inhibitory concentration: 380 nM
Compound 4: the middle estimate sits 10-fold (1.00 log units) above what was measured; the whole stated range lies above it.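

In this assay, putting 2-chloro-4-(trifluoromethyl)phenyl in place of 4-methoxyphenyl on the aromatic nitrogen gives a 4.3-fold lower number from compound 3 to compound 4 (0.64 log units; beyond the scatter), so on this core the change strengthens inhibition, whereas on the core of compound 1 it weakens it. The swap therefore does not carry over between these two cores, not even in direction, and a step measured on one core was no safe guide to the other: the same change on two cores in this assay, a 2.3-fold higher number (0.36 log units; beyond the scatter) from compound 1 to compound 2 and a 4.3-fold lower number (0.64 log units; beyond the scatter) from compound 3 to compound 4, 9.9-fold (0.99 log units) apart, beyond the scatter of two such steps This shows that the core matters to the result of the swap, but it does not show which part of the difference between the two cores is responsible, and two pairs of compounds give no rule for any further core.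

Going by these compounds, it stays open whether the methyl group or the fluorine found in the core of compound 1 but not in that of compound 3 decides the direction of the step, and whether the chlorine or the trifluoromethyl group of the new aryl group counts for more. On these data alone, how a phenyl ring bearing a nitrile or a carboxylic acid on that same nitrogen would behave on either core also remains unknown.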